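This account rests on a few compounds, and the source may have more. Where it says the series, first, only, none or still open, it means among the compounds named here.

Compound 1, `CS(=O)(=O)c1ccc(-c2cnc3ccc(-c4cccc(C(=O)N5CCC(O)CC5)c4)nn23)cc1`, gives > 200000 nM in a physicochemical assay for solubility, at pH 2; a higher number here means a more soluble compound, a lower number a less soluble compound; this is a limit of the assay, not a number.
Compound 2, `CS(=O)(=O)c1ccc(-c2cnc3ccc(-c4cccc(C(=O)NCCO)c4)nn23)cc1`, gives > 200000 nM in this assay; this too is a limit of the assay rather than a number.
Compound 3, `CS(=O)(=O)c1ccc(-c2cnc3ccc(-c4cncc(N)c4)nn23)cc1`, gives 174000 nM in this assay.

Among the three measured compounds, compound 3 stands alone as the one with an actual number in this assay; the other two sit at the limit of > 200000 nM in this assay, at which 2 of the 3 values shown sit. Among the compounds with values here, the single step between measured compounds, a step that the two limits leave unreadable from compound 1 to compound 2, cannot be read in size for that reason, so no measured step speaks directly to the change now under consideration.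

The unmeasured compound 4 is `C[S+]([O-])c1cccc(-c2ccc3ncc(-c4ccc(S(C)(=O)=O)cc4)n3n2)c1`. Its change from compound 3 is a group of 9 heavy atoms (7 carbon, 1 oxygen, 1 sulfur; one six-membered aromatic ring of carbon only) in place of a group of 7 heavy atoms (5 carbon, 2 nitrogen; one six-membered aromatic ring with 1 hetero atom), on an aromatic carbon. The group that leaves carries the one hydrogen-bond donor; the group that enters carries none, and it is built from a six-membered aromatic ring of carbon only with one sulfur and one oxygen.

With nothing measured to lean on, the account expects compound 4 to be less soluble than compound 3 in this assay, the step being a 4.4-fold lower number from compound 3 to compound 4 (0.64 log units; beyond the scatter). Compound 4 is thus estimated at 40000 nM, within a range from 8000 nM to 200000 nM.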

Compound 4, solubility: 188000 nM
Compound 4: middle estimate off by 4.7-fold (0.67 log units), on the low side, and the stated range covers the measured number.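

Within the data shown here, at this position, on an aromatic carbon of a six-membered aromatic ring with 2 nitrogen, the first readable step in this assay is a 1.1-fold higher number from compound 3 to compound 4 (0.03 log units; within the scatter), with 5-aminopyridin-3-yl replaced by a six-membered aromatic ring of carbon only with one sulfur and one oxygen. The group that leaves carries a hydrogen-bond donor and the group that enters carries none, yet the two values lie within the scatter of each other, so this exchange of rings shows no readable change. The comparisons with the two other compounds give only floors, an at least 1.0-fold lower number from compound 2 to compound 4 (0.02 log units; that floor lies within the scatter) and an at least 1.0-fold lower number from compound 1 to compound 4 (0.02 log units; that floor lies within the scatter), and the step between those two cannot be read, since each of them gives a limit of the assay and not a number: the limit of > 200000 nM in this assay, at which 2 of the 4 values shown sit.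

The compounds shown leave open whether any group at this position can bring the number clearly down, since no step here is read beyond the scatter. From the compounds shown here alone, a plain phenyl ring, a carboxylic acid or a longer alkyl chain at the same aromatic carbon lies outside these compounds, so their place remains unknown.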